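The source may report more compounds than this note shows. Statements on the series, on what has been measured and on what is new or still open speak of the compounds shown alone.

Compound 1 `C=C1C[C@]23C[C@@]1(O)CC[C@H]2c1ccc(OS(=O)(=O)c2ccc(C)cc2)c(C)c1[C@@H]3Cn1cc(-c2ccc(C)cc2)nn1`: > 20000 nM
Compound 2 `C=C1C[C@]23C[C@@]1(O)CC[C@H]2c1ccc(O)c(C)c1[C@@H]3Cn1cc(-c2ccc(C(F)(F)F)cc2)nn1`: 10400 nM
Compound 3 `C=C1C[C@]23C[C@@]1(O)CC[C@H]2c1ccc(OS(=O)(=O)c2ccc(C)cc2)c(C)c1[C@@H]3Cn1cc(-c2ccc(F)cc2)nn1`: > 20000 nM

All three were tested in a functional assay on A549 cells (Homo sapiens) for cytotoxicity, read by MTT assay, with a stated time of 4 days; a lower number here means a stronger inhibitor, a higher number a weaker inhibitor. For compound 1 the value > 20000 nM is a limit of the assay, not a number. For compound 3 the value > 20000 nM is likewise only a limit. Going by the values given here, compound 2 gives 10400 nM in this assay, the one value in the set that is a number rather than a limit. Among the compounds with values here, compound 3 therefore stands at the weak end of what the assay can read, and the one measured step that touches it, a step that the two limits leave unreadable from compound 1 to compound 3, cannot be sized because both of its ends sit at the limit of > 20000 nM in this assay, at which 2 of the 3 values shown sit.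

Compound 4 `C=C1C[C@]23C[C@@]1(O)CC[C@H]2c1ccc(OS(=O)(=O)c2ccc(C)cc2)c(C)c1[C@@H]3Cn1cc(-c2ccc(C(F)(F)F)cc2)nn1` is the next compound. It differs from compound 3 in one place: trifluoromethyl in place of fluoro on an aromatic carbon. Within the data shown here, no measured step reproduces this change on the same core, and compound 2, which carries the trifluoromethyl group, differs from compound 4 in a second place as well, so its value alone cannot guide the step. With compound 3 at a limit, the step is expected to be a step that the limit leaves unreadable from compound 3 to compound 4, most likely unreadable again. For compound 4 the estimate is 25000 nM, with a range from 8000 nM to 80000 nM, and a limit rather than a number is expected as the probable outcome.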

Compound 4, half-maximal inhibitory concentration: > 20000 nM
Compound 4: a limit, no number (the forecaster's own chance of this, stated with the estimate: 70%); the middle value does not contradict the limit.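

In this assay compound 4 gives > 20000 nM, which is a limit of the assay and not a number. Going by these compounds alone, the one readable comparison swaps hydrogen on the oxygen of the aromatic ring for (4-methylphenyl)sulfonyl, with trifluoromethyl kept in both compounds, and it gives an at least 1.9-fold higher number from compound 2 to compound 4 (0.28 log units; that floor lies within the scatter); since that floor lies within the scatter, this change cannot yet be said to weaken the compound, although the true step could be larger. The steps among compound 1, compound 3 and compound 4 cannot be read, because both ends of each sit at a limit, so methyl, fluoro and trifluoromethyl on this aromatic carbon cannot be ranked while the sulfonyl group is present: the limit of > 20000 nM in this assay, at which 3 of the 4 values shown sit.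

The compounds shown leave open how far above the limit these sulfonyl compounds lie, and whether methyl or fluoro would differ from trifluoromethyl when the oxygen carries hydrogen, as it does in compound 2. They also leave open whether an amine or a carboxylic acid on this aromatic carbon would bring a sulfonyl compound into the readable range.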